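The source may hold more compounds than are shown below. What is called first, only, known or untested is meant among the compounds shown, and "the series" means these compounds.

Compound 1 `CC1(C)[C@@H](CO)CC[C@@]1(C)Cn1cnc2c(Cl)ncnc21` — 42800 nM; compound 2 `CC1(C)[C@@H](Cn2cnc3c(N)nc(N)nc32)CC[C@@]1(C)CO` — > 200000 nM; compound 3 `Nc1ncnc2c1nnn2[C@@H]1C[C@H](CO)[C@@H](CO)[C@H]1CO` — > 200000 nM.

Going by the values given here, in an ADME assay on L1210/0 cells (Mus musculus) for cytotoxicity, with a stated time of 48 h (on this read-out higher numbers stand for weaker inhibition and lower numbers for stronger inhibition), compound 1 gives 42800 nM, the only number among the three measured compounds. Compound 2 gives > 200000 nM, which is a limit of the assay and not a number. Compound 3 gives > 200000 nM, also a limit. Among the compounds with values here, no two measured compounds differ in one place, so no measured step is available. Compound 4 `CC1(C)[C@@H](CO)CC[C@@]1(C)Cn1cnc2c(N)ncnc21` differs from compound 1 by amino in place of chloro on an aromatic carbon. Because (the limit of > 200000 nM in this assay, at which 2 of the 3 values shown sit), a step toward weaker inhibition beyond the scatter is expected from compound 1 to compound 4, namely a 3.5-fold higher number from compound 1 to compound 4 (0.54 log units; beyond the scatter). Compound 4 is thus estimated at 150000 nM in this assay, within a range from 40000 nM to 400000 nM.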

Compound 4, half-maximal inhibitory concentration: > 200000 nM
Compound 4 ended at the assay's limit; the forecaster's own chance of this, stated with the estimate: 45%; middle value at least 1.3-fold (0.12 log units) away from the limit.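

Amino in place of chloro on this aromatic carbon gives an at least 4.6-fold higher number from compound 1 to compound 4 (0.66 log units; beyond the scatter) in this assay, the first comparison here of two compounds that differ in one place. It ties the measurable inhibition of compound 1 to the chloro on this carbon of the shared core. Only a lower bound on the step can be read, since compound 4 sits at a limit of the assay: the limit of > 200000 nM in this assay, at which 3 of the 4 values shown sit.

From the compounds shown here alone, whether fluoro or bromo in the same place would keep the inhibition of compound 1 remains open. So does the effect of a methoxy or a methylamino group there.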